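The compounds below may be only part of what the source reports. "The series", "measured", "known", "first", "only" and "open" are said of these compounds alone.

Measured in an assay for inhibition of HSP60/HSP10 (Homo sapiens), with a stated time of 60 min; on this read-out higher numbers stand for weaker inhibition and lower numbers for stronger inhibition:
compound 1 `O=C(Nc1cccc(Cl)c1)c1cc(Br)cc(Br)c1O`, which in this assay gives 29000 nM;
compound 2 `O=C(Nc1cccc(Cl)c1)c1ccccc1O`, for which this assay reports only a limit, > 100000 nM;
compound 3 `O=C(Nc1ccc(Sc2nc3ccccc3s2)c(Cl)c1)c1cc(Br)cc(Br)c1`, for which this assay also reports only a limit, > 100000 nM.

Going by the values given here, compound 1 therefore stands alone as the one actual number in this assay; the other two values are not numbers but the limit of the assay, as summed up in the limit of > 100000 nM in this assay, at which 2 of the 3 values shown sit. No pair among these three differs in only one place, so no measured step is available to lean on.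

The unmeasured compound 4 `O=C(Nc1cccc(Cl)c1)c1cc(Br)cc(Br)c1` is reached from compound 1 by hydrogen in place of hydroxy on an aromatic carbon. With the two other compounds sitting at the limit and compound 1 itself only a modest number, the step is expected to run toward weaker inhibition, beyond the usual scatter, with a fair chance that this assay again reports only a limit. The expected step is a 3.1-fold higher number from compound 1 to compound 4 (0.49 log units; beyond the scatter). Compound 4 is estimated at 90000 nM, within a range from 30000 nM to 300000 nM.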

Compound 4, half-maximal inhibitory concentration: > 100000 nM
Compound 4: a limit, no number; the forecaster's own chance of this, stated with the estimate: 55%; middle value at least 1.1-fold (0.04 log units) from the limit.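

In this assay, going by these compounds alone, hydrogen in place of hydroxy on an aromatic carbon, ortho to a bromo group and ortho to a large group, gives an at least 3.4-fold higher number from compound 1 to compound 4 (0.53 log units; beyond the scatter), the first step in this set that changes only one place, and it ties the measurable inhibition of compound 1 to the hydroxy at this position. Compound 4 gives > 100000 nM, which is a limit and not a number, so the full size of the step cannot be read. Compound 1 thus remains the only compound here with an actual number: the limit of > 100000 nM in this assay, at which 3 of the 4 values shown sit.

From the compounds shown here alone, whether a methoxy group or an amine on the same carbon would retain measurable inhibition remains open. The compounds shown also offer no single-place step that isolates the contribution of either bromo group.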